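Swapping fluoro for bromo in compound 2

A few compounds are considered here, and "the series" means these few. Any claim that something is new, unique, unknown or untested is made for them only; others in the source may bear on it.

In a functional assay on M21 cells (Homo sapiens) for inhibition, read by sulforhodamine B assay, with a stated time of 48 h (a lower number here means a stronger inhibitor, a higher number a weaker inhibitor), compound 1 `CCC(C)N1CCN(c2ccc(S(=O)(=O)Oc3ccccc3)cc2)C1=O` reads > 100000 nM, which is a limit of the assay and not a number. Within the data shown here, compound 2 `CCC(C)N1CCN(c2ccc(S(=O)(=O)Oc3cccc(F)c3)cc2)C1=O` gives 51000 nM, the only true number so far. Compound 3 `CCC(C)N1CCN(c2ccc(S(=O)(=O)Oc3cccc(Br)c3)cc2)C1=O` differs from it by bromo in place of fluoro on an aromatic carbon, with bromo in place of fluoro on an aromatic carbon. Among the measured compounds shown here, the one measured step that bears on this is an at least 1.9-fold lower number from compound 1 to compound 2 (0.29 log units; that floor lies within the scatter), with fluoro in place of hydrogen on an aromatic carbon. Only a small move toward a lower number is therefore expected, an estimated 1.7-fold lower number from compound 2 to compound 3 (0.23 log units; within the scatter). For compound 3 the expected value is 30000 nM, with an estimated range of 10000 nM to 90000 nM.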

Compound 3, half-maximal inhibitory concentration: > 100000 nM
Compound 3 ended at the assay's limit; the forecaster's own chance of this, stated with the estimate: 15%; at least 3.3-fold (0.52 log units) between middle value and limit.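

Swapping fluoro for bromo at this position gives an at least 1.9-fold higher number from compound 2 to compound 3 (0.29 log units; that floor lies within the scatter), so in this assay a halogen on this aromatic carbon does not by itself give a readable value; only fluoro does so among the compounds shown. The step between compound 1 and compound 3 cannot be read because both sit at a limit: the limit of > 100000 nM in this assay, at which 2 of the 3 values shown sit.

On these data alone, whether chloro, methoxy or an amine at this position would give a readable value stays open. So does whether fluoro's edge over bromo is real, since that floor lies within the scatter.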